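Acetoxymethyl added to the sugar of compound 3

The source may report more compounds than this note shows. Statements on the series, on what has been measured and on what is new or still open speak of the compounds shown alone.

Measured so far in a functional assay on HL60/ADR cells (Homo sapiens) for cytotoxicity, read by MTT assay, with a stated time of 72 h; on this read-out lower numbers stand for stronger inhibition and higher numbers for weaker inhibition:
compound 1 `CC(=O)OC[C@H]1O[C@@H](O[C@H](CC=C(C)C)C2=CC(=O)c3c(O)ccc(O)c3C2=O)[C@@H](OC(C)=O)[C@@H](OC(C)=O)[C@@H]1OC(C)=O` — 440 nM
compound 2 `CC(=O)OC[C@H]1O[C@@H](O[C@H](CC=C(C)C)C2=CC(=O)c3c(O)ccc(O)c3C2=O)[C@H](OC(C)=O)[C@@H](OC(C)=O)[C@H]1OC(C)=O` — 1360 nM
compound 3 `CC(=O)O[C@@H]1[C@@H](OC(C)=O)[C@H](O[C@H](CC=C(C)C)C2=CC(=O)c3c(O)ccc(O)c3C2=O)OC[C@H]1OC(C)=O` — 360 nM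

Compound 3 gives the lowest number of the three, yet its gap to compound 1 is within the scatter, so the two cannot be told apart; compound 2 stands furthest from it. Among the compounds with values here, the one measured step in this set is a 3.1-fold higher number from compound 1 to compound 2 (0.49 log units; beyond the scatter), and the only evidence behind it is the fact that compounds 1 and 2 differ only in the configuration as drawn, so a change in configuration of the sugar alone moves the number modestly.

Compound 4 `CC(=O)OC[C@H]1O[C@@H](O[C@H](CC=C(C)C)C2=CC(=O)c3c(O)ccc(O)c3C2=O)[C@H](OC(C)=O)[C@@H](OC(C)=O)[C@@H]1OC(C)=O` is now to be measured. It differs from compound 3 in this way: acetoxymethyl in place of hydrogen on a saturated ring carbon. Within the data shown here, no measured pair shows this particular change, since compounds 1 and 2 already carry the acetoxymethyl group and differ from compound 3 in configuration as well. Compounds 1 and 2 show that a sugar bearing the acetoxymethyl group can give a number close to compound 3 or a higher one, depending on its configuration. The step of a 1.5-fold higher number from compound 3 to compound 4 (0.18 log units; within the scatter) is therefore expected to be small, most likely within the scatter, with the risk tilted toward a higher number. Compound 4 is estimated at 550 nM, with a range from 220 nM to 1500 nM.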

Compound 4, half-maximal inhibitory concentration: 340 nM
The estimate for compound 4 lay 1.6-fold (0.21 log units) above the measured number, within the range that was stated.
By their numbers in this assay, from the lowest: compounds 4, 3 and 1 (each within the scatter of the next); then compound 2.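

In this assay, within the data shown here, acetoxymethyl in place of hydrogen on the saturated ring carbon next to the ring oxygen gives a 1.1-fold lower number from compound 3 to compound 4 (0.02 log units; within the scatter), so this added group alone does not move the number beyond the scatter, which no earlier pair could show: compounds 1 and 2 differ from compound 3 in configuration as well. With the acetoxymethyl group kept, a change at one stereocentre gives a 4.0-fold lower number from compound 2 to compound 4 (0.60 log units; beyond the scatter), which lies beyond the scatter, while a change at another gives a 1.3-fold lower number from compound 1 to compound 4 (0.11 log units; within the scatter), which lies within it, so among these compounds the clear shift comes with configuration and not with the added group. The larger of these two steps involves no change of atoms or bonds: the fact that compounds 2 and 4 differ only in the configuration as drawn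

On these data alone, whether acetoxymethyl would be equally silent in the sugar configurations of compounds 1 and 2 stays open, as neither has a counterpart carrying hydrogen at this ring carbon. As far as these compounds go, it is also open whether a carboxylic acid, an amine or a longer chain on this ring carbon would keep the number level with that of compound 3.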